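Swapping a hydroxymethyl end for azido in compound 4

A few compounds are considered here, and "the series" means these few. Any claim that something is new, unique, unknown or untested is made for them only; others in the source may bear on it.

- Compound 1 `COC(=O)C[C@@H]1NC(=O)[C@@H](C)NC(=O)[C@@H]2Cc3ccc(OC)c(c3)Oc3ccc(cc3)C[C@@H](C(=O)N2C)N(C)C(=O)[C@H](C)NC(=O)[C@H](Cc2ccc(OC)cc2)N(C)C1=O` gives 41.7 nM in a functional assay on P388 cells (Mus musculus) for cytotoxicity; on this read-out higher numbers stand for weaker inhibition and lower numbers for stronger inhibition
- Compound 2 `COc1ccc(C[C@H]2C(=O)N[C@@H](C)C(=O)N(C)[C@H]3Cc4ccc(cc4)Oc4cc(ccc4OC)C[C@@H](C(=O)N[C@H](C)C(=O)N[C@@H](CS)C(=O)N2C)N(C)C3=O)cc1` gives 363 nM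
- Compound 3 `COc1ccc(C[C@H]2C(=O)N[C@@H](C)C(=O)N(C)[C@H]3Cc4ccc(cc4)Oc4cc(ccc4OC)C[C@@H](C(=O)N[C@H](C)C(=O)N[C@@H](CCCCO)C(=O)N2C)N(C)C3=O)cc1` gives 219 nM

These three compounds share one core and differ in a single group on a saturated chain carbon bound to a saturated ring carbon: methoxycarbonyl in compound 1, sulfanyl in compound 2 and 3-hydroxypropyl in compound 3. Compound 3 stands in the upper part of these numbers, which means weaker inhibition than compound 1 (a 5.3-fold higher number from compound 1 to compound 3 (0.72 log units; beyond the scatter)) and no real separation from compound 2 (a 1.7-fold lower number from compound 2 to compound 3 (0.22 log units; within the scatter)).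

Compound 4 `COc1ccc(C[C@H]2C(=O)N[C@@H](C)C(=O)N(C)[C@H]3Cc4ccc(cc4)Oc4cc(ccc4OC)C[C@@H](C(=O)N[C@H](C)C(=O)N[C@@H](CCCN=[N+]=[N-])C(=O)N2C)N(C)C3=O)cc1` changes only the end of the chain of compound 3: azido in place of hydroxymethyl on a saturated chain carbon, three bonds along the chain from a saturated ring carbon. Among the compounds with values here, no measured compound carries azido, so the evidence is indirect. The larger steps (an 8.7-fold higher number from compound 1 to compound 2 (0.94 log units; beyond the scatter) and a 5.3-fold higher number from compound 1 to compound 3 (0.72 log units; beyond the scatter)) both start from methoxycarbonyl, which compound 3 and compound 4 lack. The step between the two groups that replace it stayed within the scatter, so no step beyond the scatter is expected in this assay and no direction can be named. The expected step is small (a 1.1-fold higher number from compound 3 to compound 4 (0.04 log units; within the scatter)) and remains only an estimate. Compound 4 is estimated at 240 nM with an expected range from 90 nM to 650 nM on this read-out.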

Compound 4, half-maximal inhibitory concentration: 35.5 nM
The estimate for compound 4 lay 6.8-fold (0.83 log units) above the measured number; measured number below the stated range.
By their numbers in this assay, from the lowest: compounds 4 and 1 (each within the scatter of the next); then compounds 3 and 2 (each within the scatter of the next).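

In this assay, replacing the chain end gives a 6.2-fold lower number from compound 3 to compound 4 (0.79 log units; beyond the scatter), so azido in place of hydroxymethyl, on a saturated chain carbon three bonds along the chain from a saturated ring carbon, is a change this assay can detect, something the earlier swaps between sulfanyl and 3-hydroxypropyl did not reveal. Set against the shorter sulfanyl group on the carbon bound to the saturated ring carbon, the 2-azidoethyl group gives a 10-fold lower number from compound 2 to compound 4 (1.01 log units; beyond the scatter), the largest step among these compounds. Compounds 2 and 3 suggested that losing methoxycarbonyl costs inhibition, but compound 4 goes against that pattern: a 1.2-fold lower number from compound 1 to compound 4 (0.07 log units; within the scatter) shows no real separation, so methoxycarbonyl is not required for a low number in this small set.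

No measurement here bears on why azido and hydroxymethyl differ in this way. Going by these compounds, it also remains open whether an amine or a carboxylic acid at the end of the same chain, or a longer chain ending in azido, would keep the number as low as that of compound 4.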